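This account rests on a few compounds, and the source may have more. Where it says the series, first, only, none or still open, it means among the compounds named here.

Going by the values given here, in a physicochemical assay for solubility, measured as kinetic solubility, at pH 2 (a lower number here means a less soluble compound, a higher number a more soluble compound), compound 2 `CC(C)[C@H](C[C@H]1OC(=O)NC1=O)c1ccc(-c2ccc3cccc(F)c3c2)[nH]c1=O` gives 24400 nM, the highest of the three numbers so far. Compound 1 `CC(C)[C@@H](c1ccc(-c2ccc3cccc(F)c3c2)[nH]c1=O)[C@@H]1OC(=O)NC1=O` gives 6900 nM and compound 3 `CC(C)(/C=C1\OC(=O)NC1=O)c1ccc(-c2ccc3cccc(F)c3c2)[nH]c1=O` gives 1660 nM.

Compound 4 `CC(C)[C@H](C[C@@H]1OC(=O)NC1=O)c1ccc(-c2ccc3cccc(F)c3c2)[nH]c1=O` is not yet measured. Its change from compound 2 is the two compounds have the same atoms and bonds and differ only in configuration as drawn: 1 of 2 stereo elements differ; a stereocentre at a saturated ring carbon is drawn R in compound 2 and S in compound 4, so a stereocentre at a saturated ring carbon is drawn R in compound 2 and S in compound 4.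

Among the compounds with values here, no measured pair differs in configuration alone. The nearest evidence is a 3.5-fold higher number from compound 1 to compound 2 (0.55 log units; beyond the scatter), with (2,4-dioxo-1,3-oxazolidin-5-yl)methyl in place of 2,4-dioxo-1,3-oxazolidin-5-yl. That step changes the chain rather than a configuration, so it gives only a loose upper scale for the size of the change. A small shift, possibly none beyond the scatter, is expected in this assay. The expected lean is slightly downward, since compound 2 stands at the top of the series at 24400 nM.

The estimated step is a 1.5-fold lower number from compound 2 to compound 4 (0.18 log units; within the scatter). For compound 4 the expected value is 16000 nM, with an estimated range of 6000 nM to 35000 nM.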

Compound 4, solubility: 25100 nM
Beside the measured number, compound 4's estimate is 1.6-fold (0.20 log units) below it; the measured number falls inside the stated range.
By their numbers in this assay, from the lowest: compound 3; then compound 1; then compounds 2 and 4 (each within the scatter of the next).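

Going by these compounds alone, this is the first reading of configuration alone, and in this assay the ring stereocentre of the (2,4-dioxo-1,3-oxazolidin-5-yl)methyl group shows no effect beyond the scatter, with a 1.0-fold higher number from compound 2 to compound 4 (0.01 log units; within the scatter). That reading isolates the stereocentre, drawn R in one compound and S in the other: the fact that compounds 2 and 4 differ only in the configuration as drawn. The step from 2,4-dioxo-1,3-oxazolidin-5-yl to (2,4-dioxo-1,3-oxazolidin-5-yl)methyl is now seen with both drawn configurations, with a 3.5-fold higher number from compound 1 to compound 2 (0.55 log units; beyond the scatter) and a 3.6-fold higher number from compound 1 to compound 4 (0.56 log units; beyond the scatter).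

As far as these compounds go, whether the second stereo element, drawn the same in compound 2 and compound 4, would matter as little remains open. Also open, from the compounds shown here alone, is how a longer chain or a carboxylic acid in place of the (2,4-dioxo-1,3-oxazolidin-5-yl)methyl group would read in this assay.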